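Aryl swap at the shared core, cell inhibition series

The source may report more compounds than this note shows. Statements on the series, on what has been measured and on what is new or still open speak of the compounds shown alone.

Measured compounds:
compound 1 `c1ccc2c(-c3cn4ccnc4c(-c4ccc5ncn(C6CCCCC6)c5c4)n3)cccc2c1` — 6.33%
compound 2 `c1cn2cc(-c3ccsc3)nc(-c3ccc4ncn(C5CCCCC5)c4c3)c2n1` — 6.35%

In a functional assay on 786-0 cells (Homo sapiens) for inhibition, read by sulforhodamine B assay, with a stated time of 48 h, tested at 10 uM (on this read-out higher numbers stand for more inhibition at the one concentration tested (going by the name of the read-out) and lower numbers for less inhibition), compound 1 gives 6.33% and compound 2 gives 6.35%. Compound 2 holds the higher of the two numbers, but the step of a number 0 percentage points higher from compound 1 to compound 2 (within the scatter) is within the scatter, so the two values show no difference in this assay.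

Compound 3 `Clc1ccc(-c2cn3ccnc3c(-c3ccc4ncn(C5CCCCC5)c4c3)n2)cc1` is not yet measured. Its change from compound 2 is 4-chlorophenyl in place of thiophen-3-yl on an aromatic carbon. Going by the values given here, the one measured step that bears on it is the aryl exchange at the same position, a number 0 percentage points higher from compound 1 to compound 2 (within the scatter), which was flat. Exchanging one aryl group for another at this carbon has so far moved nothing, so no step beyond the scatter is expected in this assay.

The expected step is a number 0.7 percentage points higher from compound 2 to compound 3 (within the scatter). Compound 3 is therefore estimated at 7% in this assay, with a range from -8% to 22%.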

Compound 3, a percentage reported as inhibition, at one concentration (the size of the read-out at that concentration, not a potency): 12.1%
Compound 3: the middle estimate sits 5.1 percentage points below what was measured, and the stated range covers the measured number.
By their numbers in this assay, from the lowest: compounds 1, 2 and 3 (each within the scatter of the next).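

At the aromatic carbon of the shared core, 4-chlorophenyl brings a six-membered aromatic ring of carbon only alongside thiophen-3-yl and naphthalen-1-yl, and in this assay there is a number 5.8 percentage points higher from compound 2 to compound 3 (within the scatter) and a number 5.8 percentage points higher from compound 1 to compound 3 (within the scatter). A chlorine-bearing aryl group, in place of either a sulfur-containing five-membered ring or a fused naphthalene, therefore does not separate these compounds on this read-out, and the flat picture now spans three aryl groups. Nothing at hand bears on why the numbers behave this way.

Open, going by these compounds, is whether a non-aromatic group at this carbon, such as an amine or a short alkyl chain, or a carboxylic acid on the aryl ring, would give a number beyond the scatter. Also open, on these data alone, is how these compounds compare at any other concentration, since each number is a single-concentration read rather than a potency.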